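Aminoamino in place of dimethylamino on a carbonyl carbon

The compounds below may be only part of what the source reports. "The series", "measured", "known", "first", "only" and "open" are said of these compounds alone.

In a toxicity assay on HEK293 cells (Homo sapiens) for inhibition, read by resazurin assay, with a stated time of 24 h (on this read-out lower numbers stand for higher toxicity in this test and higher numbers for lower toxicity in this test), compound 1 (`O=C(NC1CCCCC1)c1ncc([N+](=O)[O-])[nH]1`) gives > 100000 nM as a limit and not a number. Compound 2 (`NC(=O)c1nc([N+](=O)[O-])cn1Cc1ccc(OC(F)(F)F)cc1`) gives > 100000 nM as a limit too. Compound 3 (`CN(C)C(=O)c1nc([N+](=O)[O-])cn1Cc1ccc(OC(F)(F)F)cc1`) gives > 100000 nM as a limit as well, and that limit is all that is known of where it stands.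

Compound 4 (`NNC(=O)c1nc([N+](=O)[O-])cn1Cc1ccc(OC(F)(F)F)cc1`) has not yet been measured. It carries aminoamino in place of the dimethylamino of compound 3 on a carbonyl carbon (aminoamino in place of dimethylamino on a carbonyl carbon).

Among the compounds with values here, one measured step touches the same carbonyl carbon: a step that the two limits leave unreadable from compound 2 to compound 3 with dimethylamino taking the place of amino. That step offers no size to carry over. What remains is the limit of > 100000 nM in this assay, at which 3 of the 3 values shown sit, for compound 1, compound 2 and compound 3 alike. Within the data shown here, no measured compound carries aminoamino, which leaves the expectation uncertain. The estimate is a number no higher from compound 3 to compound 4 (the limit leaves the size open) with no shift beyond the scatter expected in this assay and no direction that can be named. For compound 4 the expected value is 100000 nM within an estimated range from 40000 nM to 200000 nM and the result may well be only a limit again.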

Compound 4, half-maximal cytotoxic concentration: > 100000 nM
Compound 4: a limit, no number; the forecaster's own chance of this, stated with the estimate: 75%; the middle value lies on the limit itself.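

In this assay compound 4 gives > 100000 nM, which is a limit and not a number. No step among compound 2, compound 3 and compound 4 can be read, because all of them rest on the same limit: the limit of > 100000 nM in this assay, at which 4 of the 4 values shown sit.

The compounds shown leave open how far any of these carbonyl groups changes toxicity in this test.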